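A few compounds are considered here, and "the series" means these few. Any claim that something is new, unique, unknown or untested is made for them only; others in the source may bear on it.

For the measured compounds named here, compound 1 `CC1(C)c2[nH]nc(NC(=O)c3ccccc3)c2CN1Cc1ccccc1` stands second highest of the three numbers so far: in an assay on Sf21 cells for inhibition of high affinity nerve growth factor receptor (Homo sapiens), read by HTRF, with a stated time of 30 min, in the presence of a further agent that is not named here (on this read-out higher numbers stand for weaker inhibition and lower numbers for stronger inhibition), compound 1 gives 1240 nM. Compound 2 `CC1(C)c2[nH]nc(NC(=O)c3ccccc3)c2CN1Cc1cccc(I)c1`, with iodo in place of hydrogen on an aromatic carbon, gives 1360 nM, a step of a 1.1-fold higher number from compound 1 to compound 2 (0.04 log units; within the scatter). Compound 3 `CC1(C)c2[nH]nc(NC(=O)c3ccccc3)c2CN1Cc1ccccc1F`, with fluoro in place of hydrogen on an aromatic carbon, gives 450 nM, a step of a 2.8-fold lower number from compound 1 to compound 3 (0.44 log units; beyond the scatter); against compound 2 the step is a 3.0-fold lower number from compound 2 to compound 3 (0.48 log units; beyond the scatter).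

Compound 4 `CC1(C)c2[nH]nc(NC(=O)c3ccccc3)c2CN1Cc1c(F)cccc1F` differs from compound 1 by 2,6-difluorophenyl in place of phenyl on a saturated chain carbon bound to an amine nitrogen in a ring. Going by the values given here, the only measured step that bears on this is the one from compound 1 to compound 3, where a single fluoro in place of hydrogen on an aromatic carbon lowered the number by a 2.8-fold lower number from compound 1 to compound 3 (0.44 log units; beyond the scatter). Among the compounds with values here, no measured pair shows what a second fluorine on the same ring adds, so the expectation rests on that one step and is held modest. Compound 4 is therefore expected to come in near 400 nM (range 150 nM to 1100 nM), which would be a step of a 3.1-fold lower number from compound 1 to compound 4 (0.49 log units; beyond the scatter), a lowering of about the size seen from compound 1 to compound 3, with wide uncertainty on either side.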

Compound 4, half-maximal inhibitory concentration: 520 nM
Estimate against measurement, compound 4: 1.3-fold (0.11 log units) below; the measured number falls inside the stated range.
By their numbers in this assay, from the lowest: compounds 3 and 4 (each within the scatter of the next); then compounds 1 and 2 (each within the scatter of the next).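

In this assay the change to 2,6-difluorophenyl gives a 2.4-fold lower number from compound 1 to compound 4 (0.38 log units; beyond the scatter) and a 2.6-fold lower number from compound 2 to compound 4 (0.42 log units; beyond the scatter) at the same position, so the lowering first seen with one fluoro also holds with two on this ring. For the compounds shown here, the second fluoro gives a 1.2-fold higher number from compound 3 to compound 4 (0.06 log units; within the scatter) and cannot be told apart from the single fluoro on these numbers, which compound 3 alone could not show. Nothing on hand speaks to why a second fluoro leaves the number where it stood.

The compounds shown leave open whether a chloro, methoxy or trifluoromethyl group on this ring would group with compounds 3 and 4 or with compounds 1 and 2. They also leave open what an amine or a carboxylic acid on this ring, or a longer chain in place of the benzyl group, would do to the number.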